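Replacing Phenyl with Tert-Butyl on a Cytotoxicity Scaffold

The compounds below may be only part of what the source reports. "The series", "measured", "known", "first", "only" and "open" are said of these compounds alone.

Three compounds sharing one core were tested in an ADME assay on Nthy-ori 3-1 cells (Homo sapiens) for cytotoxicity, read by MTT assay, with a stated time of 10 days; a higher number here means a weaker inhibitor of growth, a lower number a stronger inhibitor of growth. Compound 1 `Nc1ncnc2c1c(-c1cc(C3CC3)on1)nn2C1CCCCC1` gives 32500 nM. Compound 2 `CC(C)n1nc(-c2cc(-c3ccccc3)on2)c2c(N)ncnc21` gives 5720 nM, the lowest of the three numbers. Compound 3 `CC(C)n1nc(/C=N/OCc2ccccc2)c2c(N)ncnc21` gives 9850 nM, which lies within the scatter of the value of compound 2, while the value of compound 1 stands beyond the scatter above that of compound 2. Among the compounds with values here, no two measured compounds differ in a single place, so no single step among them can be read.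

Compound 4 `CC(C)n1nc(-c2cc(C(C)(C)C)on2)c2c(N)ncnc21` is not yet measured. It differs from compound 2 in one place: tert-butyl in place of phenyl on an aromatic carbon. Among the measured compounds, the one carrying a small group on the five-membered aromatic ring with 1 nitrogen and 1 oxygen is compound 1, whose 32500 nM is the highest shown, though compound 1 differs elsewhere as well. An upward step is expected, a 2.1-fold higher number from compound 2 to compound 4 (0.32 log units; beyond the scatter), with thin support. Compound 4 is estimated to give 12000 nM, within 5000 nM to 35000 nM.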

Compound 4, concentration for 50% growth inhibition: 24700 nM
Compound 4: the middle estimate sits 2.1-fold (0.31 log units) below what was measured, and the stated range covers the measured number.
By their numbers in this assay, from the lowest: compounds 2 and 3 (each within the scatter of the next); then compounds 4 and 1 (each within the scatter of the next).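

In this assay, within the data shown here, this change gives the first step that can be read in a single place: tert-butyl in place of phenyl on the aromatic carbon next to the ring oxygen gives a 4.3-fold higher number from compound 2 to compound 4 (0.64 log units; beyond the scatter) and lies beyond the scatter. With the rest of compound 2 held fixed, the number therefore depends on the group at this position, and phenyl goes with the stronger inhibition of growth of the two. Nothing at hand explains this step.

Phenyl brings a ring and tert-butyl has none, so this one step cannot separate the presence of a ring from the size of the group. Going by these compounds, whether an amine or a longer chain on this carbon would give a number near that of compound 2 or near that of compound 4 remains open.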